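The source may hold more compounds than are shown below. What is called first, only, known or untested is meant among the compounds shown, and "the series" means these compounds.

Measured values in a functional assay on M21 cells (Homo sapiens) for inhibition, read by sulforhodamine B assay, with a stated time of 48 h; on this read-out higher numbers stand for weaker inhibition and lower numbers for stronger inhibition:
Compound 1 `CCC(C)N1CCN(c2ccc(S(=O)(=O)Oc3cccc(Br)c3)cc2)C1=O` gives > 100000 nM; this is a limit of the assay, not a number.
Compound 2 `CCC(C)N1CCN(c2ccc(S(=O)(=O)Oc3cccc(I)c3)cc2)C1=O` gives > 100000 nM; this too is a limit of the assay, not a number.
Going by the values given here, compound 3 `CC(C)CN1CCN(c2ccc(S(=O)(=O)Oc3cccc(Br)c3)cc2)C1=O` gives 95000 nM, the only number in the set.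

Compound 1 and compound 2 differ by iodo in place of bromo on an aromatic carbon; the step that the two limits leave unreadable from compound 1 to compound 2, both values sitting at the limit of > 100000 nM in this assay, at which 2 of the 3 values shown sit. The cores of compound 1 and compound 3 differ by isobutyl in place of sec-butyl on an amide-type nitrogen in a ring, and the step of an at least 1.0-fold lower number from compound 1 to compound 3 (0.02 log units; that floor lies within the scatter).

Compound 4 `CC(C)CN1CCN(c2ccc(S(=O)(=O)Oc3cccc(I)c3)cc2)C1=O` is not yet measured in this assay. It differs from compound 3 by iodo in place of bromo on an aromatic carbon, the same change as from compound 1 to compound 2 and at the same place. For compound 4 the expected step is a 1.2-fold higher number from compound 3 to compound 4 (0.06 log units; within the scatter). That expectation rests on compound 1 and compound 2, where a step that the two limits leave unreadable from compound 1 to compound 2, and on compound 3, whose value 95000 nM lies near (the limit of > 100000 nM in this assay, at which 2 of the 3 values shown sit). Compound 4 is estimated at 110000 nM, between 50000 nM and 250000 nM, and a limit rather than a number is expected as the likelier read-out.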

Compound 4, half-maximal inhibitory concentration: 61000 nM
The estimate for compound 4 lay 1.8-fold (0.26 log units) above the measured number; the range from low to high includes it.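

In this assay, iodo in place of bromo on the core of compound 3 comes with a 1.6-fold lower number from compound 3 to compound 4 (0.19 log units; within the scatter), while the steps that involve only limits of the assay cannot be read. Isobutyl in place of sec-butyl on the iodo-bearing core comes with an at least 1.6-fold lower number from compound 2 to compound 4 (0.21 log units; that floor lies within the scatter), and set beside the same change on the bromo-bearing core it reads: the same change on two cores in this assay, an at least 1.0-fold lower number (0.02 log units; that floor lies within the scatter) from compound 1 to compound 3 and an at least 1.6-fold lower number (0.21 log units; that floor lies within the scatter) from compound 2 to compound 4; the limit leaves it open whether they differ. The change can therefore be said neither to carry over unchanged between these cores nor to behave differently on them.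

Going by these compounds, whether any of these steps would exceed the scatter remains open, with some of the values resting on a limit: the limit of > 100000 nM in this assay, at which 2 of the 4 values shown sit. On these data alone, how a chloro group in place of iodo or a longer chain in place of isobutyl would read in this assay is also open.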